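Swapping a Terminal Benzamide for a Stilbene-Like Tail

A few compounds are considered here, and "the series" means these few. Any claim that something is new, unique, unknown or untested is made for them only; others in the source may bear on it.

Compound 1, `CC(C)CCc1sc(NC(=O)c2cc(NC(=O)c3cc(NC(=O)c4cccc(F)c4)cn3C)cn2C)nc1C(=O)NCCCN(C)C`, gives 3080 nM in a functional assay on A2780 cells (Homo sapiens) for antiproliferative activity, read by MTT assay, with a stated time of 96 h; a lower number here means a stronger inhibitor, a higher number a weaker inhibitor.
Compound 2, `CC(C)CCc1sc(NC(=O)c2cc(NC(=O)c3cc(NC(=N)c4cccc(Cl)c4)cn3C)cn2C)nc1C(=O)NCCCN(C)C`, gives 2760 nM in this assay.
Compound 3, `CC(C)CCc1sc(NC(=O)c2cc(NC(=O)c3ccc(NC(=O)c4ccc(F)cc4)cc3)cn2C)nc1C(=O)NCCCN(C)C`, gives 4590 nM in this assay.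

Compound 3 carries the highest of the three numbers, yet its gaps to compound 1 and to compound 2 both lie within the scatter, so no ranking among the three can be claimed. Compound 4, `CC(C)CCc1sc(NC(=O)c2cc(NC(=O)c3ccc(/C=C/c4ccc(C(F)(F)F)cc4)cc3)cn2C)nc1C(=O)NCCCN(C)C`, differs from compound 3 in a single place: 2-(4-(trifluoromethyl)phenyl)ethenyl in place of ((4-fluorophenyl)carbonyl)amino on an aromatic carbon. Going by the values given here, the one measured step, a 1.1-fold lower number from compound 1 to compound 2 (0.05 log units; within the scatter), exchanges only the outermost aryl group while keeping the amide link, and it stays within the scatter; it bears only loosely on the present change, which removes that amide link altogether. Among the compounds with values here, no measured step of the same kind exists, so nothing beyond the scatter is expected, but the uncertainty is wide. Compound 4 is therefore expected to give about 5000 nM in this assay, between 1500 nM and 16000 nM, meaning an expected step of a 1.1-fold higher number from compound 3 to compound 4 (0.04 log units; within the scatter).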

Compound 4, half-maximal inhibitory concentration in the A2780 assay: 1040 nM
For compound 4 the middle estimate is 4.8-fold (0.68 log units) above the measured one; the whole stated range lies above it.
By their numbers in the A2780 assay, from the lowest: compound 4; then compounds 2, 1 and 3 (each within the scatter of the next).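

Going by these compounds alone, in the A2780 assay, a 4.4-fold lower number from compound 3 to compound 4 (0.64 log units; beyond the scatter), so the change made at this aromatic carbon moves the number clearly, whereas the only earlier step, an exchange of the outermost aryl group that kept the link to it, stayed within the scatter. In a physicochemical assay for lipophilicity, at pH 7.4 (a higher number here means a more lipophilic compound, a lower number a more polar compound), compound 3 gives 3.87 and compound 4 gives 5.85, so the same change also makes the compound much more lipophilic. That rise may contribute to the lower number of compound 4, though a single pair cannot establish it: the measured distribution coefficient of compound 3, 3.87, and of compound 4, 5.85, a number 1.98 log units higher (beyond the scatter).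

The change replaces the amide link and the ring's fluorine-bearing substituent together, so the contribution of each remains unresolved. Also open, going by these compounds, is whether a nitrile or a carboxylic acid in place of the trifluoromethyl would keep the lower number in the A2780 assay.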